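Fluoro-to-nitro step checked at a second position

This account rests on a few compounds, and the source may have more. Where it says the series, first, only, none or still open, it means among the compounds named here.

Of the compounds shown here, three have been measured in a functional assay on T98G cells (Homo sapiens) for cytotoxicity, read by MTT assay, with a stated time of 48 h; on this read-out higher numbers stand for weaker inhibition and lower numbers for stronger inhibition. Compound 1 `CC(=NNC(=S)Nc1ccccc1F)c1ccccn1` gives 3.1 nM, the lowest of the three numbers. Compound 3 `CC(=NNC(=S)Nc1cccc(F)c1)c1ccccn1` gives 12 nM; compound 1 and compound 3 are built from the same atoms joined differently, and the difference between the two cores is not broken down here. Within the data shown here, compound 2 `CC(=NNC(=S)Nc1cccc([N+](=O)[O-])c1)c1ccccn1` gives 140 nM in this assay, the highest number so far.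

One structural change is made twice among the compounds shown. From compound 3 to compound 2 it is nitro in place of fluoro on an aromatic carbon, and it produced a 12-fold higher number from compound 3 to compound 2 (1.07 log units; beyond the scatter). Compound 4 `CC(=NNC(=S)Nc1ccccc1[N+](=O)[O-])c1ccccn1` is not yet measured; it differs from compound 1 by nitro in place of fluoro on an aromatic carbon. The two changes are the same kind of change, not the same: in compound 2 the entering group sits meta to a large group, in compound 4 it sits ortho to a large group, so the measured step is only a guide.

The expectation for compound 4 in this assay rests on that single measured step. Compound 4 is expected to give 37 nM, with a range from 10 nM to 150 nM that is kept wide because the place of the change differs. The expected step is a 12-fold higher number from compound 1 to compound 4 (1.08 log units; beyond the scatter), taken in size from a 12-fold higher number from compound 3 to compound 2 (1.07 log units; beyond the scatter).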

Compound 4, half-maximal inhibitory concentration: 6.6 nM
Estimate against measurement, compound 4: 5.6-fold (0.75 log units) above; the measured number lies below the stated range.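

The step for this change on the core of compound 1 is a 2.1-fold higher number from compound 1 to compound 4 (0.33 log units; beyond the scatter), and set beside the earlier step in this assay it shows that the direction is kept while the size is not: the same change on two cores in this assay, a 12-fold higher number (1.07 log units; beyond the scatter) from compound 3 to compound 2 and a 2.1-fold higher number (0.33 log units; beyond the scatter) from compound 1 to compound 4, 5.5-fold (0.74 log units) apart, beyond the scatter of two such steps

Nitro in place of fluoro therefore gave a higher number on both cores shown, but the size of the step measured on one core cannot be carried over as a fixed increment to the other. Among these compounds, this does not show why the two steps differ, and with only two pairs it does not show how such a step would behave on any further core, since the change sits at a different place in each pair, and core and place cannot be told apart in these compounds.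

Left open is whether the same direction and the same dependence on the core would appear with other groups entering in place of fluoro, such as an amine, a methoxy group or a carboxylic acid. Also open, from the compounds shown here alone, is whether the gap between the two steps would persist in a cell line other than the one used here.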